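Exchanging One Aromatic Ring at the Assay Limit

The compounds below may be only part of what the source reports. "The series", "measured", "known", "first", "only" and "open" are said of these compounds alone.

In a toxicity assay on HeLa cells (Homo sapiens) for cytotoxicity, read by MTT assay, with a stated time of 3 h (a lower number here means a stronger inhibitor, a higher number a weaker inhibitor), compound 1 (`COc1ccc2c(c1)CCc1c(-c3ccccc3)c3n(c1-2)[B-](F)(F)[N+]1=C(c2ccc(C)s2)C(Br)=C(c2ccccc2)C1=N3`) gives > 50000 nM as a limit of the assay, not a number. Compound 2 (`COc1ccc2c(c1)CCc1c(-c3ccccc3)c3n(c1-2)[B-](F)(F)[N+]1=C(c2ccc(C)cc2)C(I)=C(c2ccccc2)C1=N3`) gives > 50000 nM as a limit too. Compound 2 thus has no exact value and sits with compound 1 at one limit (the limit of > 50000 nM in this assay, at which 2 of the 2 values shown sit).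

Compound 3 (`COc1ccc2c(c1)CCc1c(-c3ccccc3)c3n(c1-2)[B-](F)(F)[N+]1=C(c2ccc(C)s2)C(I)=C(c2ccccc2)C1=N3`) has not yet been measured. It differs from compound 2 in one place, with 5-methylthiophen-2-yl in place of 4-methylphenyl on a carbon with a double bond to nitrogen. Among the measured compounds shown here, no measured pair shows this change alone, so only an expectation is possible: no shift in this assay beyond the scatter, in either direction. Compound 2 already carries the iodo group that compound 3 keeps. Compound 1 already carries 5-methylthiophen-2-yl and gives > 50000 nM as a limit, which is the reason for expecting little change. The expected step is small (a number no higher from compound 2 to compound 3 (the limit leaves the size open)). The estimate for compound 3 is 50000 nM with an expected range from 25000 nM to 100000 nM and a limit reading is the likeliest outcome.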

Compound 3, half-maximal inhibitory concentration: > 50000 nM
Compound 3: no number, only a limit (the forecaster's own chance of this, stated with the estimate: 85%); the middle value lies on the limit itself.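

In this assay compound 3 gives > 50000 nM, a limit of the assay and not a number, and its steps from compound 1 and from compound 2 cannot be read. All three compounds stand at one limit: the limit of > 50000 nM in this assay, at which 3 of the 3 values shown sit. Left open is whether exchanging 4-methylphenyl for 5-methylthiophen-2-yl, or bromo for iodo, changes the strength of inhibition at all.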